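The source may report more compounds than this note shows. Statements on the series, on what has been measured and on what is new or still open speak of the compounds shown alone.

In an ADME assay for permeability, using PAMPA, with a stated time of 4 h, at pH 7.4 (a lower number here means that the compound crosses the layer more slowly, a higher number that the compound crosses the layer faster), compound 3 (`NC/C=C\CN(C[C@H]1Cc2ncccc2CN1)[C@H]1CCCc2cccnc21`) gives 68 nm/s and compound 1 (`NCCCCN(C[C@@H]1Cc2cccnc2CN1)[C@H]1CCCc2cccnc21`) gives 77 nm/s within the usual scatter of it. Compound 2 (`CN(C[C@@H]1Cc2ncccc2CN1)[C@H]1CCCc2cccnc21`) gives 1000 nm/s and so lies far above both. Compound 4 (`NC(=O)NC/C=C\CN(C[C@H]1Cc2ncccc2CN1)[C@H]1CCCc2cccnc21`) differs from compound 3 in one place, with carbamoyl in place of hydrogen on an amine nitrogen, which turns amino to ureido. Among the compounds with values here, no measured pair shows this change, so any forecast here is uncertain. The highest number seen so far belongs to compound 2 at 1000 nm/s and offers a rough upper guide. A modest rise is expected, an estimated step of a 2.9-fold higher number from compound 3 to compound 4 (0.47 log units; beyond the scatter) that would lie just beyond the scatter. For compound 4 the estimate is 200 nm/s with 70 nm/s to 600 nm/s as the expected range.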

Compound 4, apparent permeability: 2 nm/s
Compound 4: middle estimate off by 100-fold (2.00 log units), on the high side; the whole stated range lies above it.
By their numbers in this assay, from the lowest: compound 4; then compounds 3 and 1 (each within the scatter of the next); then compound 2.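

With carbamoyl in place of hydrogen on an amine nitrogen, turning amino to ureido, this assay shows a 34-fold lower number from compound 3 to compound 4 (1.53 log units; beyond the scatter), a large step. Within the data shown here, this is the first measured pair differing in one place, and it shows that the read-out is highly sensitive to what sits on this terminal nitrogen. Nothing measured here explains the size of this drop. Still open, as far as these compounds go, is whether another group on this nitrogen, such as acetyl or methyl, would bring a step of similar size. Also open, from the compounds shown here alone, is whether the same change would act alike on the core of compound 1.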